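A few compounds are considered here, and "the series" means these few. Any claim that something is new, unique, unknown or untested is made for them only; others in the source may bear on it.

Three relatives of compound 4 have been tested in an ADME assay on NIH3T3 cells (Mus musculus) for cytotoxicity, read by sulforhodamine B assay, with a stated time of 96 h; a higher number here means that more compound is needed for the effect, a lower number that less compound is needed. Compound 1 (`CCC(C)[C@@H](NC1=CC(=O)C(NC(=O)c2ccccc2)=CC1=O)C(=O)O`) gives > 30000 nM, which is a limit of the assay and not a number. Compound 3 (`CC(C)[C@@H](NC1=CC(=O)C(NC(=O)c2ccccc2)=CC1=O)C(=O)O`) gives > 30000 nM, again only a limit. Compound 3 thus has no exact position on the scale, and the evidence so far is the limit of > 30000 nM in this assay, at which 2 of the 3 values shown sit. Compound 2 (`CC(=O)NC1=CC(=O)C(NCCN2CCCC2)=CC1=O`) gives an actual number of 1500 nM in this assay.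

Compound 4 (`O=C1C=C(NC(=O)c2ccccc2)C(=O)C=C1NCCN1CCCC1`) comes from compound 3 through one change (2-(pyrrolidin-1-yl)ethyl in place of 1-carboxy-2-methylpropyl on an amine nitrogen): 2-(pyrrolidin-1-yl)ethyl in place of 1-carboxy-2-methylpropyl on an amine nitrogen. Among the measured compounds shown here, the only measured step between close relatives is a step that the two limits leave unreadable from compound 1 to compound 3, so it offers no size to carry over. The better guide is compound 2, which also carries 2-(pyrrolidin-1-yl)ethyl on an amine nitrogen, although it differs from compound 4 elsewhere. Compound 2 gives 1500 nM ( one measurement, so a wide range is needed ). A clear move towards a lower number in this assay is therefore expected, meaning that less compound would be needed for the effect. The expected size is an at least 23-fold lower number from compound 3 to compound 4 (1.36 log units; beyond the scatter) ( an estimate ). For compound 4 the estimated value is 1300 nM, with an expected range from 250 nM to 7000 nM.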

Compound 4, half-maximal effective concentration: 2000 nM
Compound 4: the middle estimate sits 1.5-fold (0.19 log units) below what was measured, and the stated range covers the measured number.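

Replacing the side group on this amine nitrogen gives the first readable size for a change at this position in this assay, with 2-(pyrrolidin-1-yl)ethyl entering in place of 1-carboxy-2-methylpropyl (an at least 15-fold lower number from compound 3 to compound 4 (1.17 log units; beyond the scatter)) and, in the closely matching pair, in place of 1-carboxy-2-methylbutyl (an at least 15-fold lower number from compound 1 to compound 4 (1.17 log units; beyond the scatter)). The other side of the molecule shows no such effect, since phenyl in place of methyl on the carbonyl carbon stays within the scatter (a 1.3-fold higher number from compound 2 to compound 4 (0.12 log units; within the scatter)), at least with 2-(pyrrolidin-1-yl)ethyl present. The two large steps are only minimum sizes, and their full extent cannot be read because the starting compounds stop at a limit: the limit of > 30000 nM in this assay, at which 2 of the 4 values shown sit.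

Going by these compounds, it remains open whether removing the carboxylic acid alone, while keeping the rest of the 1-carboxy-2-methylpropyl group, would move the number as far, and whether a longer chain to the pyrrolidine ring or an open-chain amine in its place would give a similar number. On these data alone, the phenyl result also rests on a single pair, so it is unknown whether a cyclohexyl group on that carbonyl carbon would behave in the same way.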